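The source may hold more compounds than are shown below. What is called first, only, known or untested is meant among the compounds shown, and "the series" means these compounds.

In a functional assay on HaCaT cells (Homo sapiens) for inhibition, read by sulforhodamine B assay, with a stated time of 48 h (a lower number here means a stronger inhibitor of growth, a higher number a weaker inhibitor of growth), compound 1 `CC1(/C=C/c2ccccc2)C=CC(=O)O1` reads 119000 nM and compound 2 `CC1(/C=C/c2ccc(C(F)(F)F)cc2)C=CC(=O)O1` reads 12100 nM while compound 3 `CC1(/C=C/c2ccc(O)cc2)C=CC(=O)O1` reads 81200 nM and so sits with compound 1 at the high end of the three numbers. Compound 4 `COc1ccc(/C=C/C2(C)C=CC(=O)O2)cc1` differs from compound 3 by methyl in place of hydrogen on an oxygen on an aromatic ring (methyl in place of hydrogen on an oxygen on an aromatic ring, so hydroxy to methoxy). Going by the values given here, no measured step makes this exact change. The nearest guide is the swap of hydrogen for hydroxy (a 1.5-fold lower number from compound 1 to compound 3 (0.17 log units; within the scatter)), which stayed within the scatter. Only trifluoromethyl moved the number clearly (a 9.8-fold lower number from compound 1 to compound 2 (0.99 log units; beyond the scatter)), and hydroxy in its place undid most of that (a 6.7-fold higher number from compound 2 to compound 3 (0.83 log units; beyond the scatter)). No step beyond the scatter is therefore expected (a 1.4-fold lower number from compound 3 to compound 4 (0.13 log units; within the scatter)). Compound 4 is estimated at 60000 nM (expected range 20000 nM to 130000 nM).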

Compound 4, concentration for total growth inhibition: 316000 nM
Compound 4: the middle estimate sits 5.3-fold (0.72 log units) below what was measured, outside the stated range (above it).
By their numbers in this assay, from the lowest: compound 2; then compounds 3 and 1 (each within the scatter of the next); then compound 4.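

In this assay, the hydroxy position turns out to be sensitive: methyl on that oxygen moves the number beyond the scatter (a 3.9-fold higher number from compound 3 to compound 4 (0.59 log units; beyond the scatter)). Methoxy also separates from hydrogen on the aromatic carbon (a 2.7-fold higher number from compound 1 to compound 4 (0.42 log units; beyond the scatter)), which hydroxy did not do, and in the opposite direction to trifluoromethyl. The gap between the methoxy and trifluoromethyl compounds is the widest step here (a 26-fold higher number from compound 2 to compound 4 (1.42 log units; beyond the scatter)). No measurement shown gives a reason for these differences. From the compounds shown here alone, whether a longer chain on that oxygen, such as ethoxy, would raise the number further remains open, as does where an amine or a carboxylic acid would fall.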